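The source may hold more compounds than are shown below. What is called first, only, known or untested is meant among the compounds shown, and "the series" means these compounds.

Three compounds share one core and differ only in the aryl group on the amide-type nitrogen: compound 1 `CCOc1ccc(NC(=O)Nc2cccc(CNc3nccnc3Cl)c2)cc1`, compound 2 `O=C(Nc1ccc(Cl)cc1)Nc1cccc(CNc2nccnc2Cl)c1` and compound 3 `CC(C)(C)c1ccc(NC(=O)Nc2cccc(CNc3nccnc3Cl)c2)cc1`. In a functional assay on MGC-803 cells (Homo sapiens) for antiproliferative activity, read by MTT assay, with a stated time of 48 h (a lower number here means a stronger inhibitor, a higher number a weaker inhibitor), compound 1 gives 7240 nM, compound 2 gives 4980 nM and compound 3 gives 4820 nM. These numbers sit close together: the step of a 1.5-fold lower number from compound 1 to compound 2 (0.16 log units; within the scatter) and the step of a 1.5-fold lower number from compound 1 to compound 3 (0.18 log units; within the scatter) are both small, and the step of a 1.0-fold lower number from compound 2 to compound 3 (0.01 log units; within the scatter) is smaller still, so compound 2 stands among numbers that cannot be told apart from one another. The next compound, compound 4 `O=C(Nc1cccc(CNc2nccnc2Cl)c1)Nc1ccc(F)c(Cl)c1`, grows out of compound 2 by the change (3-chloro-4-fluorophenyl in place of 4-chlorophenyl on an amide-type nitrogen). All three measured steps concern this same aryl group, and none of them moved the number beyond the scatter, so a step of similar size, with no clear direction, is expected in this assay. Compound 4 is therefore expected to give 4500 nM, within a range from 2500 nM to 9000 nM. The expected step is a 1.1-fold lower number from compound 2 to compound 4 (0.04 log units; within the scatter).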

Compound 4, half-maximal inhibitory concentration: 5020 nM
Beside the measured number, compound 4's estimate is 1.1-fold (0.05 log units) below it, and the stated range covers the measured number.
By their numbers in this assay, from the lowest: compounds 3, 2, 4 and 1 (each within the scatter of the next).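

In this assay, the step to a ring carrying two halogens, chloro and fluoro, is a 1.0-fold higher number from compound 2 to compound 4 (0.00 log units; within the scatter), so adding the second halogen to the 4-chlorophenyl group leaves the number unmoved within the scatter. Set against the 4-ethoxyphenyl group, the same 3-chloro-4-fluorophenyl group gives a 1.4-fold lower number from compound 1 to compound 4 (0.16 log units; within the scatter), which is also within the scatter, so this position on the amide-type nitrogen has now taken a ring with two substituents as well as rings with one, without a readable change. No evidence is available that would account for this flat response.

As far as these compounds go, all four compounds carry a substituted phenyl group here, so it remains open whether an amine or a carboxylic acid on that ring would move the number beyond the scatter. Changes elsewhere in the shared core also remain open.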